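The source may hold more compounds than are shown below. What is called first, only, known or untested is meant among the compounds shown, and "the series" means these compounds.

Of the compounds shown here, three built on one shared core have been tested in a functional assay on A549 cells (Homo sapiens) for antiproliferative activity, read by MTT assay, with a stated time of 72 h; on this read-out lower numbers stand for stronger inhibition and higher numbers for weaker inhibition. Compound 1 `O=C(Nc1ccc(Oc2ccnc3[nH]ccc23)cc1)c1cc2cccnc2n(-c2ccccc2)c1=O` gives 360 nM. Compound 2 `O=C(Nc1ccc(Oc2ccnc3[nH]ccc23)cc1)c1cc2cccnc2n(-c2ccc(Cl)cc2)c1=O`, which carries chloro in place of hydrogen on an aromatic carbon, gives 290 nM; that step is a 1.2-fold lower number from compound 1 to compound 2 (0.09 log units; within the scatter). Compound 3 `O=C(Nc1ccc(Oc2ccnc3[nH]ccc23)cc1)c1cc2cccnc2n(-c2ccc(F)c(Cl)c2)c1=O` gives 680 nM, the highest of the three numbers. The step of a 1.9-fold higher number from compound 1 to compound 3 (0.28 log units; within the scatter) stays within the scatter, while a 2.3-fold higher number from compound 2 to compound 3 (0.37 log units; beyond the scatter) is modest but beyond it.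

Compound 4 `O=C(Nc1ccc(Oc2ccnc3[nH]ccc23)cc1)c1cc2cccnc2n(-c2ccc(C(F)(F)F)cc2Cl)c1=O` differs from compound 3 by 2-chloro-4-(trifluoromethyl)phenyl in place of 3-chloro-4-fluorophenyl on an aromatic nitrogen. The measured steps that bear on this change are the two that also swap the ring on the aromatic nitrogen, a 1.9-fold higher number from compound 1 to compound 3 (0.28 log units; within the scatter) and a 2.3-fold higher number from compound 2 to compound 3 (0.37 log units; beyond the scatter), and both were small. For the measured compounds named here, no measured compound carries a trifluoromethyl group, so the direction of any change is uncertain. In this assay compound 4 is therefore expected to show a 1.0-fold higher number from compound 3 to compound 4 (0.01 log units; within the scatter), a change no larger than the usual scatter. Compound 4 is estimated at 700 nM, within a range of 320 nM to 1500 nM.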

Compound 4, half-maximal inhibitory concentration: 3230 nM
Compound 4: middle estimate off by 4.6-fold (0.66 log units), on the low side; measured number above the stated range.
By their numbers in this assay, from the lowest: compounds 2, 1 and 3 (each within the scatter of the next, the first and the last beyond it); then compound 4.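

Among phenyl, 4-chlorophenyl and 3-chloro-4-fluorophenyl, the group on the aromatic nitrogen changed the number only a little, but in this assay 2-chloro-4-(trifluoromethyl)phenyl gives a 4.8-fold higher number from compound 3 to compound 4 (0.68 log units; beyond the scatter), a 9.0-fold higher number from compound 1 to compound 4 (0.95 log units; beyond the scatter) and an 11-fold higher number from compound 2 to compound 4 (1.05 log units; beyond the scatter). This position therefore does not accept every substituted phenyl equally, and compound 4 is the weakest of the four, with its steps to all three others beyond the scatter. Nothing in the available data explains this loss of activity.

Compound 4 differs from the other compounds in both its chloro placement and its trifluoromethyl group, so the compounds shown cannot say which of these accounts for the loss. A 2-chlorophenyl or a 4-(trifluoromethyl)phenyl would separate the two, while a phenyl carrying an amine or a carboxylic acid remains an open case.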